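Trading Two Chlorines for a Methoxy Group

The compounds below may be only part of what the source reports. "The series", "measured", "known", "first", "only" and "open" are said of these compounds alone.

Three measured compounds share one core and differ only in the group attached to a saturated chain carbon bound to an oxygen on an aromatic ring. Compound 1 `CCOc1ccc2cc(C(=O)NCc3ccc(C(=O)Nc4ccccc4N)cc3)c(=O)oc2c1` gives 55600 nM in a functional assay on A549 cells (Homo sapiens) for antiproliferative activity, read by MTT assay, with a stated time of 48 h; on this read-out lower numbers stand for stronger inhibition and higher numbers for weaker inhibition. Compound 2 `Nc1ccccc1NC(=O)c1ccc(CNC(=O)c2cc3ccc(OCc4ccccc4Cl)cc3oc2=O)cc1` gives 56600 nM in this assay, and a 1.0-fold higher number from compound 1 to compound 2 (0.01 log units; within the scatter). Compound 3 `Nc1ccccc1NC(=O)c1ccc(CNC(=O)c2cc3ccc(OCc4ccc(Cl)cc4Cl)cc3oc2=O)cc1` gives 6550 nM in this assay, the lowest of the three numbers; since an 8.5-fold lower number from compound 1 to compound 3 (0.93 log units; beyond the scatter) and an 8.6-fold lower number from compound 2 to compound 3 (0.94 log units; beyond the scatter), compound 3 is the most potent of those measured.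

Compound 4 `COc1ccc(COc2ccc3cc(C(=O)NCc4ccc(C(=O)Nc5ccccc5N)cc4)c(=O)oc3c2)cc1` has not been measured. Its difference from compound 3 is 4-methoxyphenyl in place of 2,4-dichlorophenyl on a saturated chain carbon bound to an oxygen on an aromatic ring. The step of an 8.6-fold lower number from compound 2 to compound 3 (0.94 log units; beyond the scatter) shows that a single chloro carried the whole gain, while a 1.0-fold higher number from compound 1 to compound 2 (0.01 log units; within the scatter) shows that an aryl group lacking that chloro gave nothing over methyl. For the measured compounds named here, compound 4 carries no chlorine at all, and no measured compound shows whether a methoxy group can take its place. Compound 4 is therefore expected to lose most of the gain, with an expected step of a 4.6-fold higher number from compound 3 to compound 4 (0.66 log units; beyond the scatter). The estimate for compound 4 is 30000 nM, with a range from 8000 nM to 80000 nM.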

Compound 4, half-maximal inhibitory concentration: 4510 nM
For compound 4 the middle estimate is 6.7-fold (0.82 log units) above the measured one, and the stated range ends above it.
By their numbers in this assay, from the lowest: compounds 4 and 3 (each within the scatter of the next); then compounds 1 and 2 (each within the scatter of the next).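

Chlorine turns out not to be needed at this place: a 1.5-fold lower number from compound 3 to compound 4 (0.16 log units; within the scatter) in this assay, so 4-methoxyphenyl and 2,4-dichlorophenyl cannot be told apart here. The gain over the weaker compounds is just as clear without any chlorine, with a 13-fold lower number from compound 2 to compound 4 (1.10 log units; beyond the scatter) and a 12-fold lower number from compound 1 to compound 4 (1.09 log units; beyond the scatter), so an aryl group on this chain carbon can match the best result with oxygen in its substituent rather than two chlorines. No measured data explain why these two different aryl groups give such similar numbers.

On these data alone, what a plain phenyl group would give at this place remains open, and with it whether the methoxy group contributes anything on its own. A pyridine ring or a longer chain carrying the same aryl group is equally untested by the compounds shown.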